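A Second Chlorine on the Benzyl Ring

The source may report more compounds than this note shows. Statements on the series, on what has been measured and on what is new or still open speak of the compounds shown alone.

Compound 1, `COc1ccccc1/C=C(\C(=O)c1ccc(Cl)cc1)S(=O)(=O)Cc1ccc(Cl)c(Cl)c1`, gives 1000 nM in a functional assay on DU-145 cells (Homo sapiens) for inhibition, read by trypan blue exclusion, with a stated time of 96 h; on this read-out higher numbers stand for weaker inhibition of growth and lower numbers for stronger inhibition of growth.
Compound 3, `COc1ccccc1/C=C(\C(=O)c1ccc(Cl)cc1)S(=O)(=O)Cc1ccc(Cl)cc1`, gives 25000 nM in this assay.
Compound 2, `O=C(O)c1ccc(C(=O)/C(=C\c2ccc(Br)c([N+](=O)[O-])c2)SCc2ccc(Cl)cc2)cc1`, gives < 1000 nM in this assay, and that figure is a limit of the assay rather than a number.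

The step from compound 3 to compound 1 is chloro in place of hydrogen on an aromatic carbon, and it produced a 25-fold lower number from compound 3 to compound 1 (1.40 log units; beyond the scatter). The unmeasured compound 4, `O=C(O)c1ccc(C(=O)/C(=C\c2ccc(Br)c([N+](=O)[O-])c2)SCc2ccc(Cl)cc2Cl)cc1`, stands to compound 2 as compound 1 stands to compound 3: chloro in place of hydrogen on an aromatic carbon. The two changes are the same kind of change but not the same one, since in compound 1 the entering chloro sits ortho to a chloro group and meta to a large group, whereas in compound 4 it sits ortho to a large group and meta to a chloro group. The difference between the core of compound 2 and the core of compound 3 is not broken down here.

Compound 2 is known only through (the limit of < 1000 nM in this assay, at which 1 of the 3 values shown sits), so the starting point of the second step is itself uncertain. By analogy with a 25-fold lower number from compound 3 to compound 1 (1.40 log units; beyond the scatter), compound 4 is expected to show a lower number than compound 2, though a smaller step is estimated, a step that the limit leaves unreadable from compound 2 to compound 4, given that the starting point is the limit of < 1000 nM in this assay, at which 1 of the 3 values shown sits. The estimate for compound 4 in this assay is 300 nM, within a range from 50 nM to 1500 nM.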

Compound 4, concentration for 50% growth inhibition in the DU-145 assay: 1000 nM
Compound 4: the middle estimate sits 3.3-fold (0.52 log units) below what was measured, within the range that was stated.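

In the DU-145 assay, the same kind of change on the core of compound 2 gave a number no lower from compound 2 to compound 4 (the limit leaves the size open). The gain seen on the core of compound 3 therefore did not carry over to this second core: the same change on two cores in the DU-145 assay, a 25-fold lower number (1.40 log units; beyond the scatter) from compound 3 to compound 1 and a number no lower (the limit leaves the size open) from compound 2 to compound 4, at least 25-fold (1.39 log units) apart, beyond the scatter of two such steps

This does not show how large the step on the core of compound 2 really is, nor whether the difference between the two results belongs to the cores or to the different places at which the chloro enters, since the value of compound 2 is a limit of the assay and not a number: the limit of < 1000 nM in the DU-145 assay, at which 1 of the 4 values shown sits.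

The compounds shown leave open whether the result on the core of compound 2 would hold with a methyl ester or a primary amide in place of the carboxylic acid. They also leave open what the chloro does in a physicochemical assay for solubility (a lower number here means a less soluble compound, a higher number a more soluble compound), where the step cannot be read since compound 2 and compound 4 both rest on a limit of the assay: the limit of < 1000 ug/mL in the physicochemical assay, at which 2 of the 2 values shown sit. In the physicochemical assay compound 2 gives < 1000 ug/mL, which is a limit of the assay and not a number. In the physicochemical assay compound 4 gives < 1000 ug/mL, which is also a limit of the assay and not a number.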